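Trimming the heteroaryl ketone of compound 1

A few compounds are considered here, and "the series" means these few. Any claim that something is new, unique, unknown or untested is made for them only; others in the source may bear on it.

Compound 1 `CCCCCCCC/C=C\CCCCCCC(=O)c1nc2cccnc2o1` carries a long unsaturated chain ending in a ketone joined to a fused bicyclic group; in an assay on isolated protein for inhibition of Fatty-acid amide hydrolase 1 (Homo sapiens) (a higher number here means a weaker inhibitor, a lower number a stronger inhibitor), compound 1 gives 11 nM, the lowest number among the measured compounds. Compound 3 `CCCCCCCC/C=C\CCCCCCC(=O)c1nnc(-c2ccccn2)o1` gives 3000 nM in this assay. Compound 2 `O=C(O)c1cccc(CCCCCCC(=O)c2ncc(-c3ccccn3)o2)c1` reaches only a limit of the assay in this assay, > 600 nM (the limit of > 600 nM in this assay, at which 1 of the 3 values shown sits). Compound 4 `CCCCCCCC/C=C\CCCCCCC(=O)c1ncco1` keeps the chain and ketone of compound 1 but changes the ring: a group of 5 heavy atoms (3 carbon, 1 nitrogen, 1 oxygen; one five-membered aromatic ring with 2 hetero atoms) in place of a group of 9 heavy atoms (6 carbon, 2 nitrogen, 1 oxygen; one five-membered aromatic ring with 2 hetero atoms, one six-membered aromatic ring with 1 hetero atom), on a carbonyl carbon. Among the compounds with values here, no measured pair shows this exact change, so the step is expected rather than known; the expectation is a clear weakening, a 27-fold higher number from compound 1 to compound 4 (1.44 log units; beyond the scatter). Compound 4 is therefore estimated at 300 nM in this assay, within a range from 60 nM to 1500 nM.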

Compound 4, inhibition constant: 17 nM
Beside the measured number, compound 4's estimate is 18-fold (1.25 log units) above it; measured number outside the range, below it.
By their numbers in this assay, from the lowest: compounds 1 and 4 (each within the scatter of the next); then compound 3.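

Cutting the group on this carbonyl carbon down to the smaller 1,3-oxazol-2-yl costs no clear strength in this assay, where the step is a 1.5-fold higher number from compound 1 to compound 4 (0.19 log units; within the scatter). Within the data shown here, the six-membered aromatic ring of compound 1 is therefore not needed to keep this level of inhibition, something the earlier compounds could not show, as none of them formed a pair differing in one place. Nothing among the data shown accounts for this result.

Still open, as far as these compounds go, is whether adding a carboxylic acid or an amine to the 1,3-oxazol-2-yl group of compound 4 would keep its number. A shorter chain in place of its long one is equally untested here.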